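Phenyl to Thiophen-2-yl on a Shared Core

The compounds below may be only part of what the source reports. "The series", "measured", "known", "first", "only" and "open" are said of these compounds alone.

Measured so far in a functional assay on HL-60 cells (Homo sapiens) for antiproliferative activity, read by XTT assay, with a stated time of 72 h; a lower number here means a stronger inhibitor, a higher number a weaker inhibitor:
Compound 1 `Nc1nc2c(c(-c3ccccc3)cn2[C@@H]2O[C@H](CO)[C@@H](O)[C@H]2O)c(=O)[nH]1` gives > 20000 nM, which is a limit of the assay and not a number.
Compound 2 `Nc1nc(N)c2c(-c3ccco3)cn([C@@H]3O[C@H](CO)[C@@H](O)[C@H]3O)c2n1` gives > 20000 nM, again a limit.
Compound 3 `COc1nc(N)nc2c1c(-c1ccsc1)cn2[C@@H]1O[C@H](CO)[C@@H](O)[C@H]1O` gives > 20000 nM, also a limit.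

Compound 1 therefore stands nowhere in particular on a scale: its result is only a limit, and the same holds for the two companions, so that all three results sit at the limit of > 20000 nM in this assay, at which 3 of the 3 values shown sit. No two of the measured compounds differ in a single place, so no measured step can be read from them, and nothing shows how far any of them lies beyond the limit.

Compound 4 `Nc1nc2c(c(-c3cccs3)cn2[C@@H]2O[C@H](CO)[C@@H](O)[C@H]2O)c(=O)[nH]1` is the unmeasured compound. It differs from compound 1 by thiophen-2-yl in place of phenyl on an aromatic carbon. Three compounds with varied groups at this place all reached only the limit, so the step from compound 1 to compound 4 is expected to be none beyond the scatter, with compound 4 remaining at the limit as well. For compound 4 a value of 30000 nM is estimated in this assay, within a range from 10000 nM to 100000 nM. The step that the limit leaves unreadable from compound 1 to compound 4 is the expected outcome, and most likely the assay will again report only a limit.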

Compound 4, half-maximal inhibitory concentration: > 20000 nM
Compound 4: only a limit was reported (the forecaster's own chance of this, stated with the estimate: 85%); the middle value lies beyond the limit too.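

Among the compounds shown here, compound 4 gives only a limit, as compound 1 does, so the change from phenyl to thiophen-2-yl yields no step that can be read. All four compounds shown end at the same place: the limit of > 20000 nM in this assay, at which 4 of the 4 values shown sit.

On these data alone, how far any of them lies beyond that limit, and whether any group at this place would give a readable value, stays open.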